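The compounds below may be only part of what the source reports. "The series", "measured", "known", "first", "only" and "open" are said of these compounds alone.

In a functional assay on MV4-11 cells (Homo sapiens) for antiproliferative activity, read by resazurin assay, with a stated time of 72 h (a higher number here means a weaker inhibitor, a lower number a stronger inhibitor), compound 2 `Cc1ccc(-c2nc3c(c(-c4ccccc4)nn3-c3ccccc3)c(-c3ccc(O)cc3)c2C#N)cc1` gives 3300 nM. Compound 1 `COc1ccc(-c2c(C#N)c(-c3ccccc3)nc3c2c(-c2ccccc2)nn3-c2ccccc2)cc1OC` returns only a limit in this assay, > 25000 nM. Because of the limit of > 25000 nM in this assay, at which 1 of the 2 values shown sits, compound 2 holds the only numbered reading shown. Compound 3 `COc1ccc(-c2nc3c(c(-c4ccccc4)nn3-c3ccccc3)c(-c3ccc(O)cc3)c2C#N)cc1` differs from compound 2 by methoxy in place of methyl on an aromatic carbon, para to a large group. Going by the values given here, no step between measured compounds covers this exchange, so the expectation is that compound 3 stays close to compound 2, the step of a 1.2-fold higher number from compound 2 to compound 3 (0.08 log units; within the scatter) being expected to fall within the usual scatter. Compound 3 is therefore estimated at 4000 nM, with a range from 1500 nM to 12000 nM.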

Compound 3, half-maximal inhibitory concentration: 1600 nM
Estimate against measurement, compound 3: 2.5-fold (0.40 log units) above; the measured number falls inside the stated range.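

The 4-methylphenyl to 4-methoxyphenyl exchange gives a 2.1-fold lower number from compound 2 to compound 3 (0.31 log units; beyond the scatter) in this assay and so shows that the number responds to the group at this position. Going by these compounds alone, this is the first step between compounds differing in one place, and it is modest. Nothing measured here gives a reason for the step. Going by these compounds, whether an amine, a chloro group or a longer chain such as ethoxy at this position would lower the number further stays open. So does whether this exchange gives a similar step when other groups on the shared core differ.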